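Hydroxyphenyl isomer swap across two related cores

A few compounds are considered here, and "the series" means these few. Any claim that something is new, unique, unknown or untested is made for them only; others in the source may bear on it.

Measured so far, in a functional assay on HeLa cells (Homo sapiens) for cytotoxicity, read by CCK-8 assay; on this read-out lower numbers stand for stronger inhibition and higher numbers for weaker inhibition:
- compound 1 `Oc1cccc(-c2cc(-c3cccs3)cc(-c3cccc(O)c3)n2)c1` gives 1690 nM.
- compound 2 `Oc1ccc(-c2cc(-c3cccs3)cc(-c3cccc(O)c3)n2)cc1` gives 4140 nM.
- compound 3 `Oc1cccc(-c2cc(-c3ccco3)cc(-c3ccccc3O)n2)c1` gives only a limit of the assay, > 50000 nM.

The change 4-hydroxyphenyl in place of 3-hydroxyphenyl on an aromatic carbon has been measured once, as a 2.4-fold higher number from compound 1 to compound 2 (0.39 log units; beyond the scatter). The same kind of change is made on the core of compound 3 to give compound 4 `Oc1ccc(-c2cc(-c3ccco3)cc(-c3ccccc3O)n2)cc1`: 4-hydroxyphenyl in place of 3-hydroxyphenyl on an aromatic carbon. The two places are not identical: in compound 1 the changing group sits meta to a 3-hydroxyphenyl group and meta to a thiophen-2-yl group, in compound 3 meta to a 2-hydroxyphenyl group and meta to a furan-2-yl group, so this is the same kind of change, not the same change. How the cores of compound 1 and compound 3 differ is not broken down here.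

Compound 3 sits at the limit of > 50000 nM in this assay, at which 1 of the 3 values shown sits.

Because of a 2.4-fold higher number from compound 1 to compound 2 (0.39 log units; beyond the scatter), which raised the number, compound 4 is expected to stay beyond that limit. The expected step is a step that the limit leaves unreadable from compound 3 to compound 4. Compound 4 is estimated at 100000 nM, within 40000 nM to 400000 nM, most likely reported as a limit only.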

Compound 4, half-maximal inhibitory concentration: > 50000 nM
Compound 4: a limit, no number; the forecaster's own chance of this, stated with the estimate: 90%; the middle value is on the limit's open side.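

In this assay compound 4 gives only a limit of the assay, > 50000 nM. For the compounds shown here, compound 3 also stands at a limit, so no step from compound 3 to compound 4 can be read. Still open, going by these compounds, is whether 4-hydroxyphenyl in place of 3-hydroxyphenyl changes the read-out at all on the core of compound 3, and which difference between the cores of compound 1 and compound 3 matters.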